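The source may report more compounds than this note shows. Statements on the series, on what has been measured and on what is new or still open speak of the compounds shown alone.

Measured in a functional assay on Ehrlich cells (Mus musculus) for cytotoxicity, tested at 100 ug/mL; a lower number here means a weaker effect, a higher number a stronger effect of the compound at the concentration tested:
compound 1 `COc1cc(N2C(N)=C(C#N)C(/C=C/c3ccccc3)C3=C2CC(C)(C)CC3=O)cc(OC)c1OC`: 40%
compound 2 `COc1cc(N2C(N)=C(C#N)C(c3c(OC)ccc4ccccc34)C3=C2CC(C)(C)CC3=O)cc(OC)c1OC`: 30%
compound 3 `COc1cc(N2C(N)=C(C#N)C(c3ccc(OC)c4ccccc34)C3=C2CC(C)(C)CC3=O)cc(OC)c1OC`: 40%

Compound 1 stands level with compound 3 at the digits shown, the two together the highest of the three numbers. Every step among the measured set lies within the scatter: a number 10 percentage points lower from compound 1 to compound 2 (within the scatter), no change at the digits printed from compound 1 to compound 3 (within the scatter) and a number 10 percentage points higher from compound 2 to compound 3 (within the scatter). Compound 4 `COc1cc(N2C(N)=C(C#N)C(c3c(O)ccc4ccccc34)C3=C2CC(C)(C)CC3=O)cc(OC)c1OC` has not yet been measured in this assay. Against compound 1 it shows (2-hydroxynaphthalen-1-yl in place of 2-phenylethenyl on a saturated ring carbon). Going by the values given here, the steps that bear on this are the two exchanges of 2-phenylethenyl for 2-methoxynaphthalen-1-yl and for 4-methoxynaphthalen-1-yl on a saturated ring carbon, a number 10 percentage points lower from compound 1 to compound 2 (within the scatter) and no change at the digits printed from compound 1 to compound 3 (within the scatter), neither beyond the scatter. A step of comparable size is therefore expected, with no direction beyond the scatter, a number 5 percentage points lower from compound 1 to compound 4 (within the scatter). Compound 4 is estimated at 35%, with a range of 20% to 50%.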

Compound 4, a percentage reported as activity, at one concentration (the size of the read-out at that concentration, not a potency): 90%
Compound 4: the middle estimate sits 55 percentage points below what was measured; measured number outside the range, above it.
By their numbers in this assay, from the lowest: compounds 2, 1 and 3 (each within the scatter of the next); then compound 4.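

In this assay, this saturated ring carbon, which showed nothing beyond the scatter across the earlier exchanges, now gives large steps: a number 50 percentage points higher from compound 1 to compound 4 (beyond the scatter) and a number 50 percentage points higher from compound 3 to compound 4 (beyond the scatter). Going by these compounds alone, the cleanest reading is the single change of hydrogen in place of methyl on the aromatic oxygen, a number 60 percentage points higher from compound 2 to compound 4 (beyond the scatter), which ties the gain to the free hydroxy group and not to the naphthalene alone. Nothing at hand accounts for the gain.

Going by these compounds, whether an amino group in place of that hydroxy keeps the gain remains open. So does whether a read-out at one concentration carries over to potency.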